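This account rests on a few compounds, and the source may have more. Where it says the series, first, only, none or still open, it means among the compounds named here.

Measured compounds:
- compound 1 `COc1ccc(C(=O)Nc2cc(-c3ccccc3)nn2-c2ccccc2)cc1` — 420 nM
- compound 2 `O=C(Nc1cc(-c2ccccc2)nn1-c1ccccc1)c1cc([N+](=O)[O-])cc([N+](=O)[O-])c1` — "not determined" (no result reported)
- compound 3 `N#Cc1ccc(C(=O)N(C(=O)c2ccc(C#N)cc2)c2cc(-c3ccccc3)nn2-c2ccccc2)cc1` — 3050 nM

These three compounds share one core and differ only in the group attached to its nitrogen. Among the compounds with values here, in an assay on HEK293 cells for displacement of a labelled ligand from metabotropic glutamate receptor 5 (Rattus norvegicus) (on this read-out higher numbers stand for weaker inhibition and lower numbers for stronger inhibition), compound 1 gives 420 nM, the lower of the two numbers known so far. Compound 3 gives 3050 nM in this assay, a clearly higher number, and the gap between compound 1 and compound 3 lies beyond the usual scatter of repeated measurements. For compound 2 no result was reported, so nothing can be said about where it stands.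

Compound 4 `O=C(Nc1cc(-c2ccccc2)nn1-c1ccccc1)c1ccncc1` has not yet been measured. It differs from compound 1 in one place: pyridin-4-yl in place of 4-methoxyphenyl on a carbonyl carbon. Within the data shown here, no measured pair shows this particular change, so the size of the step can only be estimated from the spread of the numbers seen. A moderate weakening, somewhat beyond the scatter, is expected; the expected step is a 2.1-fold higher number from compound 1 to compound 4 (0.33 log units; beyond the scatter). Compound 4 is therefore expected to give about 900 nM in this assay, within a range from 250 nM to 3500 nM.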

Compound 4, inhibition constant: > 10000 nM
Compound 4 gave a limit, no number; the forecaster's own chance of this, stated with the estimate: 10%; middle value at least 11-fold (1.04 log units) from the limit.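

In this assay, the step from 4-methoxyphenyl to pyridin-4-yl on a carbonyl carbon is an at least 23-fold higher number from compound 1 to compound 4 (1.37 log units; beyond the scatter), a large change. This is the first step shown in which the compounds differ in only one place, and it shows that the group at this position strongly affects the read-out, even though the two groups have the same counts of hydrogen-bond donors and acceptors and neither carries a net charge. The result for compound 4 is a limit of the assay and not a number: the limit of > 10000 nM in this assay, at which 1 of the 4 values shown sits.

The compounds shown leave open whether losing the methoxy group or gaining the ring nitrogen matters more, and a plain phenyl group on the same carbonyl carbon would help separate the two. From the compounds shown here alone, how an aminophenyl group would fare at this position also remains unknown.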